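This account rests on a few compounds, and the source may have more. Where it says the series, first, only, none or still open, it means among the compounds named here.

Compound 1 `CN(C[C@H]1Cc2c(cccc2N2C[C@H]3CNC[C@H]3C2)CN1)[C@H]1CCCc2cccnc21`, compound 2 `CN(C)[C@@H]1CCN(c2cccc3c2C[C@H](CN(C)[C@H]2CCCc4cccnc42)NC3)C1` and compound 3 `CN(C)C1CCN(c2cccc3c2C[C@H](CN(C)[C@H]2CCCc4cccnc42)NC3)CC1` share one core and differ in the group on an aromatic carbon. In an ADME assay on microsomes from liver (Homo sapiens) for metabolic stability, using NADPH, with a stated time of 10 min (on this read-out higher numbers stand for a more stable compound and lower numbers for a less stable compound), compound 1 gives 86.7% and compound 3 gives 78.4%. The entry for compound 2 reads "not determined" (no result reported), so it adds no number to the comparison. Among the measured compounds shown here, only one measured step is therefore available to place compound 3, and it is a number 8.3 percentage points lower from compound 1 to compound 3 (within the scatter).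

The next compound is compound 4 `CN1CC[C@H]2CN(c3cccc4c3C[C@H](CN(C)[C@H]3CCCc5cccnc53)NC4)C[C@H]21`, and its change is a group of 9 heavy atoms (7 carbon, 2 nitrogen; 2 five-membered non-aromatic rings with 1 hetero atom each) in place of a group of 9 heavy atoms (7 carbon, 2 nitrogen; one six-membered non-aromatic ring with 1 hetero atom), on an aromatic carbon. A group with one six-membered non-aromatic ring gives way to a group with 2 five-membered non-aromatic rings with 1 hetero atom each. Compound 1 also carries a group with 2 five-membered non-aromatic rings, although it is a different group, so the step to compound 3 is the closest guide, and its size is a number 8.3 percentage points lower from compound 1 to compound 3 (within the scatter). That is a single comparison, and it stays within the scatter. No step beyond the scatter is therefore expected in this assay, with only a slight lean towards the value of compound 1. The expected change is a number 3.6 percentage points higher from compound 3 to compound 4 (within the scatter). For compound 4 the estimated value is 82%, with an expected range from 68% to 94%.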

Compound 4, percent of the compound remaining: 87.3%
Compound 4: the middle estimate sits 5.3 percentage points below what was measured; the measured number falls inside the stated range.
By their numbers in this assay, from the lowest: compounds 3, 1 and 4 (each within the scatter of the next).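

In this assay, replacing the 4-(dimethylamino)piperidin-1-yl group with a group of two five-membered non-aromatic rings gives a number 8.9 percentage points higher from compound 3 to compound 4 (within the scatter), so this rearrangement of the ring system on the aromatic carbon produces no step larger than the scatter. The two groups with five-membered rings also differ from each other, and going between them gives a number 0.6 percentage points higher from compound 1 to compound 4 (within the scatter), which shows that this position accepts three different cyclic diamine groups without a step beyond the scatter, at least in these three compounds. Nothing available here explains why the numbers fall as they do.

On these data alone, what remains open is whether this tolerance extends to quite different groups on the same aromatic carbon, such as an open-chain 2-(dimethylamino)ethylamino group, a morpholine ring or a carboxylic acid. Because the three numbers lie so close together, these compounds also cannot show which features of the group, if any, matter for this read-out, and a group that moves the number beyond the scatter would be needed to begin answering that.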